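Thiophen-3-yl gives way to 1-methyl-1H-pyrazol-5-yl

A few compounds are considered here, and "the series" means these few. Any claim that something is new, unique, unknown or untested is made for them only; others in the source may bear on it.

- compound 1 `CCCCCCCCCCCC[C@@H](O)[C@H]1CC[C@H]([C@H](O)CCCCCCCCCCNC(=O)c2ccco2)O1` gives 12900 nM
- compound 2 `CCCCCCCCCCCC[C@@H](O)[C@H]1CC[C@H]([C@H](O)CCCCCCCCCCNC(=O)c2ccsc2)O1` gives 200 nM

In a functional assay on NCI-H23 cells (Homo sapiens) for inhibition, read by colorimetric assay and sulforhodamine B assay, with a stated time of 48 h (a higher number here means a weaker inhibitor of growth, a lower number a stronger inhibitor of growth), compound 2 has the lower of the two numbers, so it is the stronger inhibitor of growth. Compound 3 `CCCCCCCCCCCC[C@@H](O)[C@H]1CC[C@H]([C@H](O)CCCCCCCCCCNC(=O)c2ccnn2C)O1` differs from it in one place: 1-methyl-1H-pyrazol-5-yl in place of thiophen-3-yl on a carbonyl carbon and nothing else. Within the data shown here, the only measured step at this carbonyl carbon is a 65-fold lower number from compound 1 to compound 2 (1.81 log units; beyond the scatter) and it is large, beyond the scatter. The entering ring has no sulfur, and neither has the furan-2-yl of compound 1. A higher number is therefore expected, with the estimated change a 15-fold higher number from compound 2 to compound 3 (1.18 log units; beyond the scatter) falling short of that measured step but beyond the scatter. For compound 3 the estimate is 3000 nM with an expected range from 500 nM to 20000 nM in this assay.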

Compound 3, concentration for 50% growth inhibition: 52.5 nM
The estimate for compound 3 lay 57-fold (1.76 log units) above the measured number; measured number outside the range, below it.
By their numbers in this assay, from the lowest: compound 3; then compound 2; then compound 1.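

In this assay the ring on this carbonyl carbon can improve on thiophen-3-yl without any sulfur, since the change gives a 3.8-fold lower number from compound 2 to compound 3 (0.58 log units; beyond the scatter) as a modest step. The two rings without sulfur also lie far apart, with a 250-fold lower number from compound 1 to compound 3 (2.39 log units; beyond the scatter) between them, so the lack of sulfur alone does not set the number at this position. No measurement here accounts for the difference between these rings.

Still open, as far as these compounds go, is whether the methyl group on the pyrazole matters, and whether a plain phenyl ring would do as well on this carbonyl carbon.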